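A Methoxyphenyl Replaces a Fluorophenyl on the Oxygen

The source may report more compounds than this note shows. Statements on the series, on what has been measured and on what is new or still open speak of the compounds shown alone.

Of the compounds shown here, two have been tested in a functional assay on the whole organism with Mus musculus as the target; on this read-out lower numbers stand for an effect already at smaller amounts and higher numbers for an effect only at larger amounts of compound. Compound 1 `O=C(NCc1ccccc1)c1cccnc1Oc1ccc(F)cc1` carries a 4-fluorophenyl on an oxygen on an aromatic ring, and in this assay compound 1 gives 0.01 mg/kg. Compound 2 `O=C(NCc1ccccc1)c1cccnc1Oc1ccccc1F` carries a 2-fluorophenyl in place of that 4-fluorophenyl, and compound 2 gives 0.01 mg/kg. Among the measured compounds shown here, the one measured step, no change at the digits printed from compound 1 to compound 2 (within the scatter), shows that swapping one fluorophenyl for the other left the dose unchanged. On the numbers shown, compound 2 stands level with compound 1, with no step between them beyond the scatter.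

Compound 3 `COc1ccc(Oc2ncccc2C(=O)NCc2ccccc2)cc1` has not yet been measured. The change is 4-methoxyphenyl in place of 2-fluorophenyl on an oxygen on an aromatic ring. For the measured compounds named here, the only step that bears on it is the one between compound 1 and compound 2, which was flat, so the ring on the oxygen has so far accepted a change of group without any shift. Going by the values given here, no measured step speaks to a methoxy group, so the uncertainty is wider. An unchanged dose is expected, giving an estimated no change at the digits printed from compound 2 to compound 3 (within the scatter). Compound 3 is therefore estimated at 0.01 mg/kg, within a range from 0.003 mg/kg to 0.04 mg/kg.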

Compound 3, minimum effective dose: 0.01 mg/kg
The estimate for compound 3 equals the measured number at the digits printed; low and high end bracket the measured number.
By their numbers in this assay, from the lowest: compounds 1, 2 and 3 (each within the scatter of the next).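

In this assay the ring on the oxygen now accepts more than a shift of fluorine around the ring: there is no change at the digits printed from compound 2 to compound 3 (within the scatter) even though the 4-methoxyphenyl has 8 heavy atoms and 1 hydrogen-bond acceptor, against 7 heavy atoms and 0 hydrogen-bond acceptors for the 2-fluorophenyl. Read as a single swap of methoxy in place of fluoro on an aromatic carbon, the result is likewise no change at the digits printed from compound 1 to compound 3 (within the scatter) and so extends the flat picture to a group other than fluoro. No separate measurement is available to explain why these three rings read alike, so this remains a plain observation.

As far as these compounds go, all three compounds carry a phenyl ring with one fluoro or methoxy group on that oxygen, so it stays open how an amine, a carboxylic acid or a longer chain such as butoxy on that ring would read. From the compounds shown here alone, the rest of the molecule is the same in all three, so the effect of changes there in this assay is also open.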